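The source may report more compounds than this note shows. Statements on the series, on what has been measured and on what is new or still open speak of the compounds shown alone.

Measured compounds:
- Compound 1, `CNc1ccc(Sc2ccc([N+](=O)[O-])cc2)c(C(=O)Nc2ccccc2OC)c1`: 302000 nM
- Compound 2, `COc1ccccc1NC(=O)c1cc(C(F)(F)F)ccc1Sc1ccc([N+](=O)[O-])cc1`: "not determined" (no result reported)
- Compound 3, `COc1ccccc1C(=O)Nc1nc(Cl)ncc1Sc1ccc([N+](=O)[O-])cc1`: 480000 nM

In an ADME assay on H9 cells (Homo sapiens) for cytotoxicity, read by MTT assay, with a stated time of 7 days (on this read-out lower numbers stand for higher toxicity in this test and higher numbers for lower toxicity in this test), compound 1 gives 302000 nM, and in this assay compound 3 gives 480000 nM; the two numbers lie within the usual scatter of each other, so neither can be called the less toxic of the pair. Compound 2 has no number at all in this assay, so there is nothing to place it against the other two.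

Compound 4, `COc1ccccc1NC(=O)c1cc(N(C)C)ccc1Sc1ccc([N+](=O)[O-])cc1`, is drawn from compound 2 by one change: dimethylamino in place of trifluoromethyl on an aromatic carbon, in words, dimethylamino in place of trifluoromethyl on an aromatic carbon. Among the compounds with values here, no measured pair shows what this kind of swap does in this assay, so the expected size of the step from compound 2 to compound 4 cannot be read from the data; without a starting number for compound 2, no direction can be claimed either beyond what compounds 1 and 3 suggest about the whole series.

On that basis compound 4 is expected to give about 300000 nM in this assay, within a range from 100000 nM to 900000 nM.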

Compound 4, half-maximal cytotoxic concentration: 182000 nM
Estimate against measurement, compound 4: 1.6-fold (0.22 log units) above, within the range that was stated.
By their numbers in this assay, from the lowest: compounds 4, 1 and 3 (each within the scatter of the next, the first and the last beyond it).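

Methyl in place of hydrogen on the nitrogen gives a 1.7-fold lower number from compound 1 to compound 4 (0.22 log units; within the scatter) in this assay, so at this position, para to the (4-nitrophenyl)sulfanyl group, the read-out does not separate dimethylamino from the methylamino group of compound 1. The swap of trifluoromethyl for dimethylamino cannot be read, since compound 2 has no number to start from. No measurement at hand offers a cause for either observation.

On these data alone, whether trifluoromethyl at this position behaves any differently from these two nitrogen groups therefore remains open. Also open, as far as these compounds go, is whether an unsubstituted amine, a carboxylic acid or a longer chain such as diethylamino in this place would stay within the scatter of compound 4 or move clearly away from it.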